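This account rests on a few compounds, and the source may have more. Where it says the series, first, only, none or still open, it means among the compounds named here.

Compound 1 `Cc1nc2cnccc2n1CC1CCN(C(=O)CC(C)c2ccccc2)CC1`: 12 nM
Compound 2 `Cc1nc2cnccc2n1CC1CCN(C(=O)N[C@H](C)c2ccccc2)CC1`: 13 nM

In a functional assay (plasma) with Oryctolagus cuniculus as the target (on this read-out higher numbers stand for weaker inhibition and lower numbers for stronger inhibition), compound 2 gives 13 nM, level with compound 1 within the scatter. The next structure is compound 3 `CCOC(=O)[C@@H](NC(=O)N1CCC(Cn2c(C)nc3cnccc32)CC1)c1ccccc1`, and the change is ethoxycarbonyl in place of methyl on a saturated chain carbon bound to an amide-type nitrogen and an aromatic carbon. Ethoxycarbonyl replaces methyl on a saturated chain carbon bound to an amide-type nitrogen and an aromatic carbon.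

Among the measured compounds shown here, the only measured step, a 1.1-fold higher number from compound 1 to compound 2 (0.03 log units; within the scatter), swaps 2-phenylpropyl for (1-phenylethyl)amino on a carbonyl carbon. That is a different change at a different place, so it sets neither size nor direction here. For the measured compounds named here, no measured compound varies the methyl. The larger group makes a modest move to a higher number the working expectation, held loosely, and the expected step is a 2.3-fold higher number from compound 2 to compound 3 (0.36 log units; beyond the scatter). For compound 3 the estimated value is 30 nM, with an expected range of 6 nM to 150 nM.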

Compound 3, half-maximal inhibitory concentration: 16 nM
Beside the measured number, compound 3's estimate is 1.9-fold (0.27 log units) above it; the measured number falls inside the stated range.
By their numbers in this assay, from the lowest: compounds 1, 2 and 3 (each within the scatter of the next).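

In this assay, ethoxycarbonyl in place of methyl on a saturated chain carbon bound to an amide-type nitrogen and an aromatic carbon gives a 1.2-fold higher number from compound 2 to compound 3 (0.09 log units; within the scatter). This position therefore accepts a group of 5 heavy atoms, carrying 2 hydrogen-bond acceptors, in place of a single carbon without a read-out change beyond the scatter. No supporting data on hand account for this level result.

The compounds shown leave open whether the read-out stays level with a carboxylic acid or an amine on this carbon, or with a plain longer chain such as propyl in place of methyl. With one replacement at this carbon, no trend with group size can be stated.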